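Methyl for Hydrogen on an Aromatic Oxygen: Compound 4

A few compounds are considered here, and "the series" means these few. Any claim that something is new, unique, unknown or untested is made for them only; others in the source may bear on it.

Compound 1 `COC(=O)c1c(-c2ccc([N+](=O)[O-])cc2)oc2ccccc2c1=O` gives > 25 ug/mL in a functional assay on SK-MEL cells (Homo sapiens) for cytotoxicity, read by MTT assay, with a stated time of 6 days; a higher number here means that more compound is needed for the effect, a lower number that less compound is needed.
Compound 2 `O=C(O)c1c(-c2ccc([N+](=O)[O-])cc2)oc2ccccc2c1=O` gives > 25 ug/mL in this assay.
Compound 3 `COc1cc(-c2cc(=O)c3cc(O)ccc3o2)cc(OC)c1OC` gives 5.87 ug/mL in this assay.

The values for compound 1 and compound 2 are limits of the assay and not numbers, which is the limit of > 25 ug/mL in this assay, at which 2 of the 3 values shown sit. Compound 1 differs from compound 2 by methyl in place of hydrogen on an oxygen next to a carbonyl group, and the step that the two limits leave unreadable from compound 2 to compound 1. Compound 3 stands alone with a number; its core differs from the core of compound 2, and the difference between the two cores is not broken down here.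

Compound 4 `COc1ccc2oc(-c3cc(OC)c(OC)c(OC)c3)cc(=O)c2c1` is not yet measured. It differs from compound 3 by methyl in place of hydrogen on an oxygen on an aromatic ring. This is the same kind of change as that from compound 2 to compound 1, not the same: there the oxygen sits next to a carbonyl group whose other neighbour is a carbonyl carbon, here on an aromatic ring whose other neighbour is an aromatic carbon. The earlier step gives no readable size to lean on. For compound 4 a step of a 1.4-fold higher number from compound 3 to compound 4 (0.13 log units; within the scatter) is expected, resting only on compound 3 at 5.87 ug/mL. Compound 4 is estimated at 8 ug/mL, between 3 ug/mL and 22 ug/mL.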

Compound 4, concentration for half-maximal effect: > 25 ug/mL
Compound 4: no number, only a limit; the forecaster's own chance of this, stated with the estimate: 15%; middle value at least 3.1-fold (0.49 log units) from the limit.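

From the compounds shown here alone, on the core that carries the hydroxy group, the change from hydroxy to methoxy gives an at least 4.2-fold higher number from compound 3 to compound 4 (0.62 log units; beyond the scatter) in this assay, so on this core the methyl on an oxygen on an aromatic ring costs a step beyond the scatter, and its full size remains unknown. Compound 4 gives > 25 ug/mL, which is a limit of the assay and not a number. The same kind of change on the other core, on an oxygen next to a carbonyl group, cannot be read, so the compounds do not show whether the step carries from one core to another, and the comparison ends at the limit: the limit of > 25 ug/mL in this assay, at which 3 of the 4 values shown sit.

Compound 3, at 5.87 ug/mL, remains the only compound shown with a number. Going by these compounds, what an amine, a carboxylic acid or a longer chain such as ethoxy would give in place of the hydroxy group on that aromatic ring stays open.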